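Sulfonyl substituent exchange in a shared-core series

The source may hold more compounds than are shown below. What is called first, only, known or untested is meant among the compounds shown, and "the series" means these compounds.

Measured so far:
- Compound 1: `C/C(=C\c1ccccc1)C(=O)N[C@@H]1C2CCN(CC2)[C@@H]1Cc1cccnc1` — > 10000 nM in an assay on a protein complex for binding affinity to Neuronal acetylcholine receptor; alpha4/beta2 (Homo sapiens); a lower number here means a stronger inhibitor, a higher number a weaker inhibitor
- Compound 2: `O=S(=O)(N[C@@H]1C2CCN(CC2)[C@@H]1Cc1cccnc1)c1ccc(Br)cc1` — > 10000 nM

Compound 1 sits at the limit of this assay with > 10000 nM, a limit and not a number. Compound 2 likewise returns > 10000 nM, again a limit of this assay rather than a measured figure. For the measured compounds named here, both entries therefore rest on (the limit of > 10000 nM in this assay, at which 2 of the 2 values shown sit), and no quantified step between them exists; the two structures differ in more than one place, so nothing about any single change can be read from them.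

The next compound, compound 3, is `O=S(=O)(Cc1ccccc1)N[C@@H]1C2CCN(CC2)[C@@H]1Cc1cccnc1`. It differs from compound 2 in one place only: benzyl in place of 4-bromophenyl on a sulfonyl sulfur, in words benzyl in place of 4-bromophenyl on a sulfonyl sulfur. Going by the values given here, no measured step gives guidance on such an exchange. The expected change a number no higher from compound 2 to compound 3 (the limit leaves the size open) is none beyond the usual scatter, since compound 2 already sits at the limit and no evidence points the other way. Compound 3 is therefore expected at 10000 nM, within 3000 nM to 30000 nM, most probably reported once more only as a limit.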

Compound 3, inhibition constant: > 10000 nM
Compound 3 was reported as a limit (the forecaster's own chance of this, stated with the estimate: 75%); the middle value sits exactly at the limit.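

Compound 3 gives > 10000 nM in this assay, a limit and not a number. No step between compound 2 and compound 3 can be read, because both rest on the same limit: the limit of > 10000 nM in this assay, at which 3 of the 3 values shown sit.

The compounds shown leave open whether any substituent on the sulfonyl sulfur of the shared core gives a quantifiable affinity.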